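This account rests on a few compounds, and the source may have more. Where it says the series, first, only, none or still open, it means among the compounds named here.

The shared core of compound 1 `O=S(=O)(Nc1ccc(-c2nc3ccccc3o2)cc1)c1ccc(Cl)s1` carries a sulfonamide whose sulfonyl sulfur bears a 5-chlorothiophen-2-yl group. In an ADME assay on HEK293 cells (Homo sapiens) for cytotoxicity, read by resazurin assay, with a stated time of 48 h (on this read-out higher numbers stand for lower toxicity in this test and lower numbers for higher toxicity in this test), compound 1 shows only a limit, > 100000 nM, the highest point this test reports (the limit of > 100000 nM in this assay, at which 1 of the 3 values shown sits). Two comparison compounds place the sulfonamide differently on the core: compound 2 `Cc1ccccc1S(=O)(=O)Nc1ccc2oc(-c3ccccc3)nc2c1` gives 57000 nM in this assay, and compound 3 `O=S(=O)(Nc1ccc2oc(-c3ccccc3)nc2c1)c1cccc(F)c1` gives 68000 nM. Between them lies a single change, a 1.2-fold higher number from compound 2 to compound 3 (0.08 log units; within the scatter), a swap of one aryl group on the sulfonyl sulfur that leaves the number unmoved. Within the data shown here, compound 4 `COc1ccc(S(=O)(=O)Nc2ccc(-c3nc4ccccc4o3)cc2)cc1` arises from compound 1 by a related swap: 4-methoxyphenyl in place of 5-chlorothiophen-2-yl on a sulfonyl sulfur No measured step follows this exact change, and the one step that is known concerns another position of the sulfonamide. From it, a swap of the aryl on the sulfonyl sulfur is expected to move the read-out little, so the step is estimated as a number no higher from compound 1 to compound 4 (the limit leaves the size open). Compound 4 is therefore expected to give about 100000 nM, between 40000 nM and 250000 nM, most likely again as a limit.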

Compound 4, half-maximal cytotoxic concentration: > 100000 nM
Compound 4: a limit, no number (the forecaster's own chance of this, stated with the estimate: 60%); the middle value sits exactly at the limit.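

Compound 1 and compound 4 both give a limit rather than a number, so no step can be read between them: the limit of > 100000 nM in this assay, at which 2 of the 4 values shown sit.

The compounds shown leave open whether 4-methoxyphenyl in place of 5-chlorothiophen-2-yl on a sulfonyl sulfur changes the half-maximal cytotoxic concentration at all.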